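The source may report more compounds than this note shows. Statements on the series, on what has been measured and on what is new or still open speak of the compounds shown alone.

Compounds measured in an assay on cells for binding affinity to Neuropeptide Y receptor type 1 (Homo sapiens); on this read-out lower numbers stand for stronger inhibition and higher numbers for weaker inhibition:
- compound 1 `CCc1sc(CCc2cc(OC)cc(NCc3cc(Cl)cc(NC(=O)OC(C)C)c3)n2)nc1C`: 234 nM
- compound 2 `CCc1sc(CCc2cc(OC(C)C)cc(NCc3cc(Cl)cc(NC(=O)OC(C)C)c3)n2)nc1C`: 12 nM

For the measured compounds named here, compound 1 stands at the top of these two numbers; in this assay compound 1 gives 234 nM, and its only neighbour, compound 2, gives 12 nM. Going by the values given here, the single measured step between them, a 20-fold lower number from compound 1 to compound 2 (1.29 log units; beyond the scatter), is large and beyond the scatter.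

Compound 3 `CCc1sc(CCc2cc(OC3CCOCC3)cc(NCc3cc(Cl)cc(NC(=O)OC(C)C)c3)n2)nc1C` is not yet measured. It differs from compound 1 in one place: oxan-4-yl in place of methyl on an oxygen on an aromatic ring. The change sits on the same oxygen on an aromatic ring that was altered in the step from compound 1 to compound 2, where a larger group also entered in place of methyl. Among the compounds with values here, that step, a 20-fold lower number from compound 1 to compound 2 (1.29 log units; beyond the scatter), is therefore the one piece of evidence that bears on compound 3, and it points to a step of comparable size in the same direction, toward a lower number.

On that basis the value of compound 3 in this assay is estimated at 20 nM, with a range from 5 nM to 80 nM. The expected step is then a 12-fold lower number from compound 1 to compound 3 (1.07 log units; beyond the scatter).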

Compound 3, half-maximal inhibitory concentration: 4.4 nM
Beside the measured number, compound 3's estimate is 4.5-fold (0.66 log units) above it; the measured number lies below the stated range.
By their numbers in this assay, from the lowest: compound 3; then compound 2; then compound 1.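

In this assay, the oxygen on an aromatic ring carries a group far larger than isopropyl without any loss, and oxan-4-yl in place of methyl gives a 53-fold lower number from compound 1 to compound 3 (1.73 log units; beyond the scatter). The trend also continues past isopropyl: oxan-4-yl in place of isopropyl gives a 2.7-fold lower number from compound 2 to compound 3 (0.44 log units; beyond the scatter), a modest step but one beyond the scatter, so isopropyl does not mark the end of the gain at this position. Oxan-4-yl differs from isopropyl in both its ring and its ring oxygen, and these three compounds cannot tell the two features apart. No supporting data are available to explain either step.

The compounds shown leave open whether the ring oxygen matters at all, a question that cyclohexyl, with carbon in its place, would address directly. They also leave open how far the trend extends on this oxygen, for instance to piperidin-4-yl, which carries an amine in the ring, or to a longer chain such as 2-methoxyethyl.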